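Compound 3: swapping acetyl for methoxy

The compounds below may be only part of what the source reports. "The series", "measured", "known", "first", "only" and "open" are said of these compounds alone.

Measured so far in a functional assay on CCRF-CEM cells (Homo sapiens) for antiproliferative activity, read by cell counting, with a stated time of 96 h; on this read-out lower numbers stand for stronger inhibition and higher numbers for weaker inhibition
- compound 1 `CC(Nc1ccccc1Oc1ccc(Cl)cc1)=C1C(=O)CC(c2ccccc2)CC1=O` gives 190 nM
- compound 2 `CC(=O)c1ccc(Oc2ccccc2NC(C)=C2C(=O)CC(c3ccccc3)CC2=O)cc1` gives 220 nM

Among the compounds with values here, compound 2 stands within the scatter of compound 1, the only other measured compound, so the two cannot be ordered. The next compound, still unmeasured, is compound 3 `COc1ccc(Oc2ccccc2NC(C)=C2C(=O)CC(c3ccccc3)CC2=O)cc1`, which has methoxy in place of acetyl on an aromatic carbon, para to a large group methoxy in place of acetyl on an aromatic carbon in comparison with compound 2. Within the data shown here, one measured step bears on this change: a 1.2-fold higher number from compound 1 to compound 2 (0.06 log units; within the scatter), an exchange on the same aromatic carbon. Among the measured compounds shown here, that step stayed within the scatter, although methoxy itself has no measured precedent here. No step beyond the scatter is therefore expected in this assay, in either direction. The expected step is a 1.1-fold lower number from compound 2 to compound 3 (0.04 log units; within the scatter) and remains an estimate. For compound 3 the estimated value is 200 nM, with an expected range from 90 nM to 450 nM in this estimate.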

Compound 3, half-maximal inhibitory concentration: 120 nM
Beside the measured number, compound 3's estimate is 1.7-fold (0.22 log units) above it, and the stated range covers the measured number.
By their numbers in this assay, from the lowest: compounds 3, 1 and 2 (each within the scatter of the next).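

In this assay methoxy on the aromatic carbon para to a large group gives a 1.8-fold lower number from compound 2 to compound 3 (0.26 log units; within the scatter) when it replaces acetyl and a 1.6-fold lower number from compound 1 to compound 3 (0.20 log units; within the scatter) when it replaces chloro, and both steps lie within the scatter. This position now holds three different groups, chloro, acetyl and methoxy, with no step beyond the scatter among them, so compounds 1, 2 and 3 cannot be ordered. Methoxy, which had no measured precedent here, fits the picture left by the earlier exchange of acetyl for chloro.

On these data alone, whether an amine, a carboxylic acid or a longer chain at this position would also stay within the scatter remains open, as does the effect of the same exchanges elsewhere on the shared core. No measurement at hand speaks to what lies behind these readings.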